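This account rests on a few compounds, and the source may have more. Where it says the series, first, only, none or still open, it means among the compounds named here.

Of the compounds shown here, three with a shared core have been measured in a functional assay for antagonist activity at 5-hydroxytryptamine receptor 4 (Rattus norvegicus); a higher number here means a more potent compound, by a factor of ten per unit of this negative logarithm, a lower number a less potent compound. Compound 1 `COc1ccc(COc2cc(N)c(Cl)cc2C(=O)CCCCN2CCCCC2)cc1` gives 8.4. Compound 2 `COc1ccc(CCOc2cc(N)c(Cl)cc2C(=O)CCCCN2CCCCC2)cc1OC` gives 6.8, and the step of a number 1.60 log units lower from compound 1 to compound 2 (beyond the scatter) shows that a change at the benzyl ether end of the molecule can matter a great deal. Compound 3 `CCCC1CCN(CCCCC(=O)c2cc(Cl)c(N)cc2OCc2cc(OC)cc(OC)c2)CC1` gives 7.7, which places it second of the three values: compound 1 is the nearer neighbour, and compound 2 lies furthest away. Compound 3 differs from compound 1 in two places at once, so the numbers alone cannot be split between those two changes.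

Compound 4 `COc1cc(COc2cc(N)c(Cl)cc2C(=O)CCCCN2CCC(C(N)=O)CC2)cc(OC)c1` differs from compound 3 in one place: carbamoyl in place of propyl on a saturated ring carbon. For the measured compounds named here, none of the measured steps touches this saturated ring carbon, so there is no direct guide to the size of this step in this assay. Going by the values given here, the only known step, from compound 1 to compound 2, concerns a different part of the core. A change of this kind may go either way, and the expected step of a number 0.30 log units lower from compound 3 to compound 4 (within the scatter) is therefore set close to zero with a wide range. Compound 4 is estimated to give about 7.4, somewhere between 6.4 and 8.4.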

Compound 4, negative logarithm of the antagonist equilibrium constant: 8.4
For compound 4 the middle estimate is 1.00 log units below the measured one; low and high end bracket the measured number.
By their numbers in this assay, from the lowest: compound 2; then compound 3; then compounds 1 and 4 (each within the scatter of the next).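

In this assay, swapping propyl for carbamoyl on this saturated ring carbon, three ring bonds from the ring nitrogen, gives a step of a number 0.70 log units higher from compound 3 to compound 4 (beyond the scatter) and so shows that this position responds to the group it carries. For the compounds shown here, the earlier compounds could not show this, as their only single-place step lay at the benzyl ether end of the molecule. The two groups have the same count of 3 heavy atoms, but carbamoyl also brings a nitrogen, an oxygen, a double bond, a hydrogen-bond donor and a hydrogen-bond acceptor, so the step goes with a change in the kind of atoms and not in their number. Nothing measured here gives a reason for the rise.

Going by these compounds alone, with only this one pair at the position, it remains open whether a carboxylic acid, a primary amine or a hydroxyl group on the same carbon would give a similar step, or whether a longer chain than propyl would lower or raise the number. On these data alone, it is also open whether carbamoyl would give the same step with the 4-methoxyphenyl group of compound 1 at the other end of the molecule.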